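Sulfonamide in Place of Triazole: Expected Cell Toxicity

A few compounds are considered here, and "the series" means these few. Any claim that something is new, unique, unknown or untested is made for them only; others in the source may bear on it.

Measured so far:
Compound 1 `CN(CCC#N)C[C@H]1CN(c2ccc(-n3cc(-c4ccccn4)cn3)c(F)c2)C(=O)O1`: > 400 ug/mL
Compound 2 `O=C1O[C@@H](Cn2ccnn2)CN1c1ccc(-n2cc(-c3ccccn3)cn2)c(F)c1`: 49 ug/mL

Both compounds were tested in an ADME assay on L02 cells (Homo sapiens) for cytotoxicity, read by MTT assay, with a stated time of 48 h; on this read-out higher numbers stand for weaker inhibition and lower numbers for stronger inhibition. For compound 1 the result is a limit of the assay, > 400 ug/mL, not a number. For the measured compounds named here, compound 2 gives 49 ug/mL in this assay, the only outright number in the set, so it stands as the single fixed point. Going by the values given here, the one measured step, an at least 8.1-fold lower number from compound 1 to compound 2 (0.91 log units; beyond the scatter), runs toward stronger inhibition; since it rests on (the limit of > 400 ug/mL in this assay, at which 1 of the 2 values shown sits), only a lower bound on its size is known.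

Compound 3 `CS(=O)(=O)NC[C@H]1CN(c2ccc(-n3cc(-c4ccccn4)cn3)c(F)c2)C(=O)O1` has not yet been measured. It differs from compound 2 in one place: methanesulfonamido in place of 1H-1,2,3-triazol-1-yl on a saturated chain carbon bound to a saturated ring carbon. Among the compounds with values here, no measured step concerns a triazole giving way to a sulfonamide; the step from compound 1 to compound 2 changed a different group at the same place, so it offers no direction for this exchange. Compound 3 is therefore expected to give about 120 ug/mL in this assay, within a range from 35 ug/mL to 400 ug/mL. That estimate means an expected step of a 2.4-fold higher number from compound 2 to compound 3 (0.39 log units; beyond the scatter), leaning toward weaker inhibition but with wide uncertainty.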

Compound 3, half-maximal inhibitory concentration: > 400 ug/mL
Compound 3: no number, only a limit; the forecaster's own chance of this, stated with the estimate: 30%; at least 3.3-fold (0.52 log units) between middle value and limit.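

Placing methanesulfonamido where compound 2 carries 1H-1,2,3-triazol-1-yl, on a saturated chain carbon bound to a saturated ring carbon, gives an at least 8.1-fold higher number from compound 2 to compound 3 (0.91 log units; beyond the scatter), a move toward weaker inhibition in this assay. Taken with the earlier step, this shows that the lower number does not follow from just any change at this position: of the three groups shown here, only the triazole of compound 2 gives a number that lies inside the range of the assay, while (2-cyanoethyl)(methyl)amino and methanesulfonamido both leave the read-out at its limit. Compound 3 gives > 400 ug/mL, which is a limit and not a number, so the new step is known only as a lower bound, and the step between the two compounds that sit at the limit, compound 1 and compound 3, cannot be read: the limit of > 400 ug/mL in this assay, at which 2 of the 3 values shown sit.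

Going by these compounds, how far those two compounds lie beyond the limit remains unknown, so they cannot be ranked against each other. An acetamido group or a pyrazole ring at the same place would help to show whether the lower number belongs to the triazole itself or to a wider set of groups.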